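Hydroxyl position on the aryl arms and cell growth inhibition

The source may hold more compounds than are shown below. What is called first, only, known or untested is meant among the compounds shown, and "the series" means these compounds.

Measured in a functional assay on T47D cells (Homo sapiens) for cytotoxicity, read by CCK-8 assay, with a stated time of 4 days; a lower number here means a stronger inhibitor, a higher number a weaker inhibitor:
compound 1 `Oc1ccc(-c2cc(-c3ccccc3O)cc(-c3ccccc3O)n2)cc1`, 960 nM
compound 2 `Oc1cccc(-c2cc(-c3ccccc3O)cc(-c3ccccc3O)n2)c1`, 5760 nM
compound 3 `Oc1ccc(-c2cc(-c3cccc(O)c3)nc(-c3ccccc3O)c2)cc1`, 4810 nM

Compound 2 and compound 3 differ in the core by 4-hydroxyphenyl in place of 2-hydroxyphenyl on an aromatic carbon, and a 1.2-fold lower number from compound 2 to compound 3 (0.08 log units; within the scatter). From compound 2 to compound 1 the change is 4-hydroxyphenyl in place of 3-hydroxyphenyl on an aromatic carbon, with a 6.0-fold lower number from compound 2 to compound 1 (0.78 log units; beyond the scatter). Compound 4 `Oc1ccc(-c2cc(-c3ccc(O)cc3)nc(-c3ccccc3O)c2)cc1` is not yet measured; it arises from compound 3 by 4-hydroxyphenyl in place of 3-hydroxyphenyl on an aromatic carbon. This is the same kind of change as from compound 2 to compound 1, not the same: there the place is meta to two 2-hydroxyphenyl groups, here it is meta to a 2-hydroxyphenyl group and to a 4-hydroxyphenyl group. Among the measured compounds shown here, for compound 4 a step of roughly a 4.0-fold lower number from compound 3 to compound 4 (0.60 log units; beyond the scatter) in this assay is expected, resting on the only precedent, compound 2 to compound 1 with a 6.0-fold lower number from compound 2 to compound 1 (0.78 log units; beyond the scatter), tempered for the different surroundings. Compound 4 is estimated at 1200 nM, between 400 nM and 3500 nM.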

Compound 4, half-maximal inhibitory concentration: 50000 nM
The estimate for compound 4 lay 42-fold (1.62 log units) below the measured number, outside the stated range (above it).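

In this assay the change to 4-hydroxyphenyl from 3-hydroxyphenyl does not carry from one core to the other, since a 10-fold higher number from compound 3 to compound 4 (1.02 log units; beyond the scatter) reverses the direction of the earlier step: the same change on two cores in this assay, a 6.0-fold lower number (0.78 log units; beyond the scatter) from compound 2 to compound 1 and a 10-fold higher number (1.02 log units; beyond the scatter) from compound 3 to compound 4, 62-fold (1.79 log units) apart, beyond the scatter of two such steps.
The change to 4-hydroxyphenyl from 2-hydroxyphenyl does not carry either, with a 52-fold higher number from compound 1 to compound 4 (1.72 log units; beyond the scatter) set against an earlier step of no clear effect: the same change on two cores in this assay, a 1.2-fold lower number (0.08 log units; within the scatter) from compound 2 to compound 3 and a 52-fold higher number (1.72 log units; beyond the scatter) from compound 1 to compound 4, 62-fold (1.79 log units) apart, beyond the scatter of two such steps.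
The effect of each change thus depends on the other arms in these four compounds, but with one pair per core this gives no rule and no reason for the reversal.

On these data alone, it remains open whether the same dependence appears in further arm combinations. As far as these compounds go, it is also open whether it survives replacing a hydroxyl with an amine or a methoxy group.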